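A few compounds are considered here, and "the series" means these few. Any claim that something is new, unique, unknown or untested is made for them only; others in the source may bear on it.

Of the compounds shown here, three have been measured in a functional assay for inhibition of sodium/hydrogen exchanger (Oryctolagus cuniculus); on this read-out higher numbers stand for weaker inhibition and lower numbers for stronger inhibition. Compound 1 `CS(=O)(=O)c1cc(C(=O)N=C(N)N)c(Cl)cc1Cl` gives 140 nM in this assay, compound 2 `Cc1c(C(=O)N=C(N)N)cc(S(C)(=O)=O)c(Cl)c1[N+](=O)[O-]` gives 44 nM, and compound 3 `CCC(C)c1cc(C)c(C(=O)N=C(N)N)cc1S(C)(=O)=O` gives 8 nM. Compound 3 thus stands lowest of the three; compound 2 is its nearest neighbour and lies beyond the scatter from it, and compound 1 lies further still. Compound 4 `COc1cc(C)c(C(=O)N=C(N)N)cc1S(C)(=O)=O` has not yet been measured. It differs from compound 3 in one place: methoxy in place of sec-butyl on an aromatic carbon. For the measured compounds named here, no step between two measured compounds that differ in a single place is available, so the size of this change cannot be read from a precedent. Going by the values given here, compound 3 is the only one carrying the sec-butyl group and gives the lowest number, 8 nM, while compound 1 and compound 2, which lack it, give higher numbers. The step of a 2.5-fold higher number from compound 3 to compound 4 (0.40 log units; beyond the scatter) is therefore expected to be a modest shift toward weaker inhibition, though a result within the scatter would not surprise. Compound 4 is estimated at 20 nM, with a range from 5 nM to 80 nM.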

Compound 4, half-maximal inhibitory concentration: 16 nM
Compound 4: the middle estimate sits 1.3-fold (0.10 log units) above what was measured, and the stated range covers the measured number.
By their numbers in this assay, from the lowest: compounds 3 and 4 (each within the scatter of the next); then compound 2; then compound 1.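

In this assay, for the compounds shown here, the single-place step a 2.0-fold higher number from compound 3 to compound 4 (0.30 log units; within the scatter) gives the first direct reading at this aromatic carbon, ortho to a methylsulfonyl group. The step stays within the scatter, so the two compounds cannot be told apart, and the sec-butyl group is not needed for a number at this level: methoxy, with 2 heavy atoms and 1 hydrogen-bond acceptor, stands level with a group of 4 carbon atoms and no acceptor. No measurement at hand explains why these two groups read alike.

On these data alone, whether the position accepts groups of other kinds remains open, since an amine, a carboxylic acid or a longer chain at this carbon could still move the number beyond the scatter. This single step also cannot show whether the methyl group or the methylsulfonyl group shapes the outcome at this position.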